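Methylamino in Place of Hydroxy on a Carbonyl Carbon

A few compounds are considered here, and "the series" means these few. Any claim that something is new, unique, unknown or untested is made for them only; others in the source may bear on it.

Of the compounds shown here, three from this study have been tested in a functional assay on A549 cells (Homo sapiens) for inhibition, read by sulforhodamine B assay, with a stated time of 72 h; on this read-out lower numbers stand for stronger inhibition of growth and higher numbers for weaker inhibition of growth. Compound 1 `Cn1ncc2cc(-c3cnccc3/C=C/C(=O)O)ccc21` carries a carboxy group on a double-bonded chain carbon; in this assay compound 1 gives > 10000 nM, which is a limit of the assay and not a number. Compound 3 `O=C(O)CCc1ccncc1-c1ccc2ccccc2c1` carries a carboxy group on a saturated chain carbon; in this assay compound 3 gives > 10000 nM, again a limit. Compound 2 `CNC(=O)CCc1ccncc1-c1ccc2ccccc2c1` is its methylcarbamoyl counterpart, and in this assay compound 2 gives 10400 nM. The step that the limit leaves unreadable from compound 3 to compound 2 therefore cannot be sized, because the limit of > 10000 nM in this assay, at which 2 of the 3 values shown sit, hides where compound 3 truly lies. The difference between the cores of compound 1 and compound 3 is not broken down here.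

The unmeasured compound 4 `CNC(=O)/C=C/c1ccncc1-c1ccc2c(cnn2C)c1` arises from compound 1 by methylamino in place of hydroxy on a carbonyl carbon. This is the same kind of change as methylamino in place of hydroxy on a carbonyl carbon, though the surroundings differ: in compound 1 the carbonyl carbon sits on a double-bonded chain carbon, in compound 3 on a saturated chain carbon.

Going by the values given here, the expectation for compound 4 rests on the single comparable pair, where compound 2 with 10400 nM stayed weak after the change. It also takes into account that compound 1 shows only a limit in this assay. On that basis the step from compound 1 to compound 4 is estimated at a step that the limit leaves unreadable from compound 1 to compound 4. Compound 4 is accordingly expected to show about 12000 nM, plausibly between 4000 nM and 40000 nM.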

Compound 4, concentration for 50% growth inhibition: > 10000 nM
Compound 4 ended at the assay's limit (the forecaster's own chance of this, stated with the estimate: 50%); the middle value does not contradict the limit.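

No step can be read from compound 1 to compound 4, because both compounds stand only at a limit in this assay: the limit of > 10000 nM in this assay, at which 3 of the 4 values shown sit.

The compounds shown leave open where compound 1, compound 3 and compound 4 truly lie in this assay, and so whether methylamino in place of hydroxy on a carbonyl carbon changes growth inhibition at all in either surrounding.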